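This account rests on a few compounds, and the source may have more. Where it says the series, first, only, none or still open, it means among the compounds named here.

Measured so far in a functional assay on the whole organism (Tail, strain ICR) with Mus musculus as the target, in the tail flick test, with a stated time of 120 min, at a dose of 25 umol/kg by the oral route; on this read-out higher numbers stand for a stronger effect at the one dose given and lower numbers for a weaker effect:
Compound 1, `O=C(O)[C@@H]1CCCN1C(=O)CN(c1nc(Cl)nc2[nH]cnc12)C1CC1` — 23.6%
Compound 2, `C[C@H](NC(=O)CN(c1nc(Cl)nc2[nH]cnc12)C1CC1)C(=O)O` — 28.4%
Compound 3, `C[C@H](NC(=O)CN(c1nc(Cl)nc2[nH]cnc12)C1CC1)C(=O)OCc1ccccc1` — 36.1%

Compound 2 sits between the other two numbers, and both of its neighbours lie within the scatter of it: a number 4.8 percentage points higher from compound 1 to compound 2 (within the scatter) and a number 7.7 percentage points higher from compound 2 to compound 3 (within the scatter). Compound 4, `CC(C)C[C@H](NC(=O)CN(c1nc(Cl)nc2[nH]cnc12)C1CC1)C(=O)O`, differs from compound 2 in one place: isopropyl in place of hydrogen on a saturated chain carbon, two bonds along the chain from an amide-type nitrogen and a carbonyl carbon. Neither measured step bears directly on this change; one swaps the whole amino-acid part, the other the ester end, and both stayed within the scatter. With the three numbers so close together, no step beyond the scatter is expected in this assay. Compound 4 is therefore estimated at 30%, with a range from 15% to 45%. The expected step is a number 1.6 percentage points higher from compound 2 to compound 4 (within the scatter).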

Compound 4, a percentage reported as activity, at one dose (the size of the read-out at that dose, not a potency): 18.7%
The estimate for compound 4 lay 11.3 percentage points above the measured number, and the stated range covers the measured number.
By their numbers in this assay, from the lowest: compounds 4, 1, 2 and 3 (each within the scatter of the next, the first and the last beyond it).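

In this assay, isopropyl in place of hydrogen on this saturated chain carbon, which turns methyl into isobutyl, gives a number 9.7 percentage points lower from compound 2 to compound 4 (within the scatter). The earlier compounds shown here showed no change at this carbon, and this first change leaves compound 4 within the usual scatter of compound 2, so the isobutyl chain is tolerated at this position. Nothing measured here points to a cause for this step.

Going by these compounds, an amine, a hydroxyl group or a longer chain on this same carbon remains open. So does whether a benzyl ester of compound 4 would read differently from its acid.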